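Flipping the ring fusion of compound 3 and permeability

The compounds below may be only part of what the source reports. "The series", "measured", "known", "first", "only" and "open" are said of these compounds alone.

Of the compounds shown here, three share one core and have been measured in an ADME assay on Caco-2 cells (Homo sapiens) for permeability, read by LC-MS, in the apical to basolateral direction, with a stated time of 60 min, at pH 6.5; a lower number here means that the compound crosses the layer more slowly, a higher number that the compound crosses the layer faster. Compound 1 `CC1(C[C@@H](O)C(=O)N2C[C@H]3C[C@H]3[C@H]2C(=O)NCc2cc(Cl)ccc2-n2cnnn2)CC1` gives 2.2 10^-6 cm/s. Compound 2 `O=C(NCc1cc(Cl)ccc1-n1cnnn1)[C@@H]1[C@H]2C[C@H]2CN1C(=O)[C@H](O)c1ccccc1` gives 12 10^-6 cm/s. Compound 3 `CC(C)(C)[C@@H](O)C(=O)N1C[C@@H]2C[C@@H]2[C@H]1C(=O)NCc1cc(Cl)ccc1-n1cnnn1` gives 17 10^-6 cm/s, the highest of the three numbers; its gap to compound 2 is within the scatter, while its gap to compound 1 is beyond it. Within the data shown here, the only single-change step among them, a 1.4-fold higher number from compound 2 to compound 3 (0.15 log units; within the scatter), shows that swapping the side-chain group left the number essentially where it was.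

Compound 4 `CC(C)(C)[C@@H](O)C(=O)N1C[C@H]2C[C@H]2[C@H]1C(=O)NCc1cc(Cl)ccc1-n1cnnn1` has not yet been measured. It differs from compound 3 only in configuration: the two compounds have the same atoms and bonds and differ only in configuration as drawn: 2 of 4 stereo elements differ; a stereocentre at a saturated ring carbon is drawn R in compound 3 and S in compound 4; a stereocentre at a saturated ring carbon is drawn S in compound 3 and R in compound 4. Among the measured compounds shown here, no measured step here changes a stereocentre, so the data give no direct guide to this change; the one measured step shows that a sizeable change elsewhere stayed within the scatter. Compound 4 is therefore expected to stay close to compound 3, with a step of a 1.2-fold lower number from compound 3 to compound 4 (0.08 log units; within the scatter) that does not clearly exceed the scatter. The estimate for compound 4 in this assay is 14 10^-6 cm/s, within a range from 6 10^-6 cm/s to 30 10^-6 cm/s.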

Compound 4, apparent permeability: 3.8 10^-6 cm/s
Estimate against measurement, compound 4: 3.7-fold (0.57 log units) above; measured number below the stated range.
By their numbers in this assay, from the lowest: compounds 1 and 4 (each within the scatter of the next); then compounds 2 and 3 (each within the scatter of the next).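

In this assay, among these compounds, changing only the two ring stereocentres gives a 4.5-fold lower number from compound 3 to compound 4 (0.65 log units; beyond the scatter), a step beyond the scatter and the first measured change of configuration. Side-chain swaps behave differently: with the ring configuration of compound 4, tert-butyl in place of (1-methylcyclopropyl)methyl gives a 1.7-fold higher number from compound 1 to compound 4 (0.24 log units; within the scatter), which is within the scatter, as was a 1.4-fold higher number from compound 2 to compound 3 (0.15 log units; within the scatter) with the ring configuration of compound 3. The drop from compound 3 to compound 4 can be traced to configuration alone, because no group enters or leaves: the fact that compounds 3 and 4 differ only in the configuration as drawn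

Going by these compounds, the phenyl and (1-methylcyclopropyl)methyl groups each appear here with one ring configuration only, so it remains open whether the same change would shift their numbers as far. Nor do the compounds shown tell how a side chain carrying an amine or a carboxylic acid would respond.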